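The source may hold more compounds than are shown below. What is called first, only, known or untested is meant among the compounds shown, and "the series" means these compounds.

Compound 1 `O=[N+]([O-])c1cccc(CNc2cc(Br)cc3[nH]ncc23)c1`: in an assay for inhibition of Indoleamine 2,3-dioxygenase 1 (Homo sapiens), with stated times of 10 min and 60 min (on this read-out higher numbers stand for weaker inhibition and lower numbers for stronger inhibition), compound 1 gives 7950 nM. Compound 2 `O=[N+]([O-])c1cccc(CNc2cc(C(F)(F)F)cc3[nH]ncc23)c1`: in this assay compound 2 gives > 100000 nM, which is a limit of the assay and not a number. Compound 3 `NCCn1ncc2c(NCc3ccccc3[N+](=O)[O-])cc(C(F)(F)F)cc21`: in this assay compound 3 gives > 100000 nM, again a limit and not a number.

Compound 2 thus stands at the limit of > 100000 nM in this assay, at which 2 of the 3 values shown sit, and how far beyond that boundary it lies is not known. Within the data shown here, the only measured step is an at least 12-fold higher number from compound 1 to compound 2 (1.09 log units; beyond the scatter), trifluoromethyl in place of bromo on an aromatic carbon, and it runs toward this limit. Compound 4 `O=C(O)c1cccc(CNc2cc(C(F)(F)F)cc3[nH]ncc23)c1` differs from compound 2 by carboxy in place of nitro on an aromatic carbon. Among the measured compounds shown here, no measured step touches this change; the step from compound 1 to compound 2 concerns another part of the molecule and says only that compound 2 reaches the limit. Compound 4 is therefore expected to sit near the same limit. The estimate for compound 4 is 100000 nM, expected to fall between 30000 nM and 300000 nM. That estimate corresponds to an expected step of a number no higher from compound 2 to compound 4 (the limit leaves the size open).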

Compound 4, half-maximal inhibitory concentration: > 100000 nM
Compound 4: only a limit was reported (the forecaster's own chance of this, stated with the estimate: 70%); the middle value sits exactly at the limit.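

Among these compounds, compound 2 and compound 4 both stand at a limit of this assay and not at a number, so no step between them can be read: the limit of > 100000 nM in this assay, at which 3 of the 4 values shown sit. The compounds shown leave open how far past that limit each lies, and so whether carboxy in place of nitro alters inhibition at all.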